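Ethylamino in Place of Tert-butoxy: An Expected Value

This account rests on a few compounds, and the source may have more. Where it says the series, first, only, none or still open, it means among the compounds named here.

Of the compounds shown here, two have so far been measured in a functional assay on the whole organism (strain CD1) for inhibition, with Mus musculus as the target, with stated times of 15 min and 20 min, at a dose of 10 mg/kg by the subcutaneous route; a higher number here means more inhibition at the dose given (going by the name of the read-out), a lower number less inhibition. Compound 1 `N#C/C(=C\c1ccoc1)C(=O)O` gives 30.7%, and compound 2 `CC(C)(C)OC(=O)/C(C#N)=C/c1ccoc1` gives 81.8%. Within the data shown here, compound 2 thus stands highest of the two numbers, separated from compound 1 by the single step of a number 51.1 percentage points higher from compound 1 to compound 2 (beyond the scatter). The unmeasured compound 3 `CCNC(=O)/C(C#N)=C/c1ccoc1` differs from compound 2 in one place: ethylamino in place of tert-butoxy on a carbonyl carbon. Among the measured compounds shown here, no measured step exchanges the group on the carbonyl carbon in this way, so the guidance is indirect. The step of a number 51.1 percentage points higher from compound 1 to compound 2 (beyond the scatter) shows that the group on the carbonyl carbon moves this assay strongly, so a shift beyond the scatter is plausible, with the direction uncertain because compound 1 gave 30.7% with a different group there. Compound 3 is expected to give 60%, within 30% to 90%. This expectation corresponds to a step of a number 21.8 percentage points lower from compound 2 to compound 3 (beyond the scatter).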

Compound 3, a percentage reported as inhibition, in the whole organism at one dose (the size of the read-out at that dose, not a potency): 31%
The estimate for compound 3 lay 29 percentage points above the measured number; the range from low to high includes it.
By their numbers in this assay, from the lowest: compounds 1 and 3 (each within the scatter of the next); then compound 2.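

In this assay, ethylamino in place of tert-butoxy on the carbonyl carbon gives a number 50.8 percentage points lower from compound 2 to compound 3 (beyond the scatter), so the high reading of compound 2 does not carry over to this amide. Ethylamino in place of hydroxy gives a number 0.3 percentage points higher from compound 1 to compound 3 (within the scatter), so this assay does not separate these two groups at this place. Of the three groups now seen on the carbonyl carbon, only tert-butoxy stands apart from the others, which the first pair alone could not show, and no measurement available here bears on the reason for this.

Open, on these data alone, is whether a methyl ester or a tert-butylamino group on the carbonyl carbon would read with compound 2 or with compound 3. That would help to show whether the tert-butyl group or the ester oxygen goes with the high reading of compound 2.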